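Phenyl on the sulfamoyl nitrogen of compound 1

The compounds below may be only part of what the source reports. "The series", "measured", "known", "first", "only" and "open" are said of these compounds alone.

Compound 1 `NS(=O)(=O)N1CCC(C(=O)/C(=N/O)Nc2ccc(F)c(Br)c2)CC1` stands second highest of the three numbers in an assay on tissue (HeLa cells) for inhibition of Indoleamine 2,3-dioxygenase 1 (Homo sapiens), with a stated time of 48 h (a lower number here means a stronger inhibitor, a higher number a weaker inhibitor), where compound 1 gives 45 nM. Compound 3 `NS(=O)(=O)NC[C@H]1CC[C@H](C(=O)/C(=N/O)Nc2ccc(F)c(Br)c2)CC1` gives 21 nM, and compound 2 `O=C(Nc1ccccc1)[C@H]1CC[C@H](C(=O)/C(=N/O)Nc2ccc(F)c(Br)c2)CC1` gives 197 nM. Compound 4 `O=C(/C(=N/O)Nc1ccc(F)c(Br)c1)C1CCN(S(=O)(=O)Nc2ccccc2)CC1` differs from compound 1 by phenyl in place of hydrogen on a sulfonamide nitrogen, that is, sulfamoyl to phenylsulfamoyl. Among the measured compounds shown here, no measured pair shows exactly this change. For the measured compounds named here, the one step that bears on it is a 9.4-fold lower number from compound 2 to compound 3 (0.97 log units; beyond the scatter), in which a free sulfamoyl group on the saturated ring side takes the place of a phenyl-bearing amide; compound 1 and compound 3, both carrying a free sulfamoyl group, give the two lower numbers of the set, while compound 2, carrying the phenyl-bearing group, gives the highest. Going by the values given here, putting a phenyl onto the sulfamoyl nitrogen of compound 1 is therefore expected to raise the number, by a step of about a 2.4-fold higher number from compound 1 to compound 4 (0.39 log units; beyond the scatter), smaller than the one seen between compound 2 and compound 3, since the change here is only the added phenyl and no measured pair shows it. Compound 4 is estimated at 110 nM, with a range from 40 nM to 350 nM.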

Compound 4, half-maximal inhibitory concentration: 150 nM
Estimate against measurement, compound 4: 1.4-fold (0.13 log units) below; the range from low to high includes it.
By their numbers in this assay, from the lowest: compound 3; then compound 1; then compounds 4 and 2 (each within the scatter of the next).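

Phenyl in place of hydrogen on the sulfonamide nitrogen, taken alone, costs potency in this assay: the step is a 3.3-fold higher number from compound 1 to compound 4 (0.52 log units; beyond the scatter), modest but beyond the scatter. The earlier step, a 9.4-fold lower number from compound 2 to compound 3 (0.97 log units; beyond the scatter), changed the whole group on the saturated ring carbon, whereas this pair isolates the added phenyl and shows that this nitrogen accepts an aromatic ring while inhibition stays measurable, with compound 4 at 150 nM. Nothing shown accounts for the rise in the number.

The compounds shown leave open whether a smaller group such as methyl, or a longer chain such as benzyl, on this nitrogen would cost as much as phenyl. Also open, as far as these compounds go, is whether phenyl on the sulfamoyl nitrogen of compound 3 would give a step of similar size.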